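The compounds below may be only part of what the source reports. "The series", "measured", "known", "first", "only" and "open" are said of these compounds alone.

Compound 3 `O=C1c2c[n+]([O-])c3ccccc3c2C(=O)c2c1c1ccccc1n2CCCN1CCC(O)CC1` stands second highest of the three numbers seen so far in a functional assay on HCT-116 cells (Homo sapiens) for cytotoxicity, read by MTT assay, with a stated time of 72 h; a higher number here means a weaker inhibitor, a lower number a stronger inhibitor: compound 3 gives 190 nM. Compound 2 `CC1(C)OC[C@H](Cn2cc(Cn3c4c(c5ccccc53)C(=O)c3c[n+]([O-])c5ccccc5c3C4=O)nn2)O1` gives 130 nM, and these two values lie within the scatter of each other. Among the measured compounds shown here, compound 1 `CN1CCN(CCCCCCn2c3c(c4ccccc42)C(=O)c2c[n+]([O-])c4ccccc4c2C3=O)CC1` gives 2900 nM, and the one measured step, a 15-fold lower number from compound 1 to compound 3 (1.18 log units; beyond the scatter), was large and beyond the scatter. For the measured compounds named here, compound 4 `O=C1c2c[n+]([O-])c3ccccc3c2C(=O)c2c1c1ccccc1n2Cc1cn(C[C@H](O)CO)nn1` differs from compound 3 by 1-(2,3-dihydroxypropyl)-1H-1,2,3-triazol-4-yl in place of 2-(4-hydroxypiperidin-1-yl)ethyl on a saturated chain carbon bound to an aromatic nitrogen, a change in the same chain region that the one measured step altered. That step shows this region can move the number strongly, yet compound 2, which also carries a triazolylmethyl group on that aromatic nitrogen, sits within the scatter of compound 3. The step is therefore expected to be small, a 1.3-fold lower number from compound 3 to compound 4 (0.10 log units; within the scatter). Compound 4 is estimated at 150 nM, ranging from 60 nM to 400 nM.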

Compound 4, half-maximal inhibitory concentration: 400 nM
For compound 4 the middle estimate is 2.7-fold (0.43 log units) below the measured one; measured number inside the range.
By their numbers in this assay, from the lowest: compounds 2 and 3 (each within the scatter of the next); then compound 4; then compound 1.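

In this assay, (1-(2,3-dihydroxypropyl)-1H-1,2,3-triazol-4-yl)methyl in place of 3-(4-hydroxypiperidin-1-yl)propyl gives a 2.1-fold higher number from compound 3 to compound 4 (0.32 log units; beyond the scatter), so the triazole does not simply match the piperidine chain here. What the triazole carries also counts: 1,2-dihydroxyethyl in place of 2,2-dimethyl-1,3-dioxolan-4-yl gives a 3.1-fold higher number from compound 2 to compound 4 (0.49 log units; beyond the scatter). Even so, the diol keeps much of the advantage over the long piperazine chain, with a 7.3-fold lower number from compound 1 to compound 4 (0.86 log units; beyond the scatter). Nothing available explains these shifts. From the compounds shown here alone, how a triazole bearing a primary amine or a carboxylic acid instead of the diol would behave remains open.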